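Trading Pentafluorophenyl for 3-Fluorophenyl

A few compounds are considered here, and "the series" means these few. Any claim that something is new, unique, unknown or untested is made for them only; others in the source may bear on it.

Among the measured compounds shown here, in a functional assay on MCF7 cells (Homo sapiens) for inhibition, read by MTT assay, with a stated time of 48 h (a lower number here means a stronger inhibitor of growth, a higher number a weaker inhibitor of growth), compound 2 `CN1CC[C@H](c2c(O)cc(O)c3c(=O)cc(/C=C/c4c(F)c(F)c(F)c(F)c4F)oc23)[C@H](O)C1` gives 8000 nM as the lower of the two numbers so far. Compound 1 `CN1CC[C@H](c2c(O)cc(O)c3c(=O)cc(/C=C/c4ccccc4)oc23)[C@H](O)C1` gives 31000 nM and stands higher. Compound 3 `CN1CC[C@H](c2c(O)cc(O)c3c(=O)cc(/C=C/c4cccc(F)c4)oc23)[C@H](O)C1` brings 3-fluorophenyl in place of 2,3,4,5,6-pentafluorophenyl on a double-bonded chain carbon bound to a double-bonded chain carbon with 3-fluorophenyl in place of 2,3,4,5,6-pentafluorophenyl on a double-bonded chain carbon bound to a double-bonded chain carbon. For the measured compounds named here, the only measured step bearing on this is a 3.9-fold lower number from compound 1 to compound 2 (0.59 log units; beyond the scatter) on placing 2,3,4,5,6-pentafluorophenyl where phenyl stood. Part of that modest step is expected to be given back, so a 2.1-fold higher number from compound 2 to compound 3 (0.33 log units; beyond the scatter) is the estimated change in this assay toward a higher number. Compound 3 is estimated at 17000 nM with an expected range from 7000 nM to 40000 nM for its measurement.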

Compound 3, concentration for 50% growth inhibition: 3000 nM
Compound 3: middle estimate off by 5.7-fold (0.75 log units), on the high side, outside the stated range (below it).
By their numbers in this assay, from the lowest: compound 3; then compound 2; then compound 1.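

Placing 3-fluorophenyl where 2,3,4,5,6-pentafluorophenyl stood gives a 2.7-fold lower number from compound 2 to compound 3 (0.43 log units; beyond the scatter) in this assay, while fluoro in place of hydrogen on an aromatic carbon gives a 10-fold lower number from compound 1 to compound 3 (1.01 log units; beyond the scatter). Across these three compounds, the number therefore does not fall steadily with the count of fluorine atoms: compound 3, with one, stands lowest, and compound 2, with five, stands between it and compound 1. Nothing available explains this order. Going by these compounds, whether fluoro itself matters remains open, and 3-chlorophenyl or 3-methoxyphenyl would bear on that. On these data alone, what 4-fluorophenyl would give is also open.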